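This account rests on a few compounds, and the source may have more. Where it says the series, first, only, none or still open, it means among the compounds named here.

Compound 3 `C#CCNC1CCc2c(SCc3ccc(Br)cc3)cccc21` gives the lowest of the two numbers in an ADME assay on isolated protein for inhibition of Amine oxidase [flavin-containing] B (Homo sapiens) (a lower number here means a stronger inhibitor, a higher number a weaker inhibitor), at 488 nM. Its nearest neighbour is compound 1 `C#CCNC1CCc2c(SCc3cccc(F)c3)cccc21`, which in this assay gives 11600 nM; the step is a 24-fold lower number from compound 1 to compound 3 (1.38 log units; beyond the scatter), covering both the substituent and its place on the ring. Compound 2 `C#CCNC1CCc2c(SCc3cccc(C)c3)cccc21` reaches only a limit of the assay, > 100000 nM, and not a number (the limit of > 100000 nM in this assay, at which 1 of the 3 values shown sits). The other steps are an at least 8.6-fold higher number from compound 1 to compound 2 (0.93 log units; beyond the scatter) and an at least 200-fold lower number from compound 2 to compound 3 (2.31 log units; beyond the scatter).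

Compound 4 `C#CCNC1CCc2c(SCc3ccc(C(F)(F)F)cc3)cccc21` differs from compound 3 by trifluoromethyl in place of bromo on an aromatic carbon. For the measured compounds named here, no measured step changes one substituent for another at this same place, so none bears on it directly; the measured steps only show that the aryl substituent moves this assay strongly. A modest step is therefore expected, most likely toward a somewhat higher number, as a 2.5-fold higher number from compound 3 to compound 4 (0.39 log units; beyond the scatter). Compound 4 is estimated at 1200 nM in this assay, with a range from 300 nM to 5000 nM.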

Compound 4, half-maximal inhibitory concentration: 930 nM
Compound 4: middle estimate off by 1.3-fold (0.11 log units), on the high side, within the range that was stated.
By their numbers in this assay, from the lowest: compounds 3 and 4 (each within the scatter of the next); then compound 1. At a limit, above all of these: compound 2.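

Trifluoromethyl in place of bromo gives a 1.9-fold higher number from compound 3 to compound 4 (0.28 log units; within the scatter) in this assay, so this exchange at this place on the aromatic ring cannot be told apart from the scatter, although the entering group has 4 heavy atoms and the leaving one 1. The earlier steps shown here changed the substituent and its place together, or worked at another place, and showed only that the aryl substituent moves the number strongly; this pair isolates one exchange at one place and shows no such movement. No measured property at hand accounts for this result.

From the compounds shown here alone, whether an amine or a carboxylic acid at this same place would also leave the number unmoved stays open. Also open, going by these compounds, is how bromo or trifluoromethyl would behave at the ring place that carries fluoro in compound 1.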